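The source may report more compounds than this note shows. Statements on the series, on what has been measured and on what is new or still open speak of the compounds shown alone.

Of the compounds shown here, three have so far been measured in an assay on BTI cells for inhibition of Amine oxidase [flavin-containing] B (Homo sapiens), read by fluorescence, with stated times of 30 min and 1 h, tested at 1 uM; a higher number here means more inhibition at the concentration tested (going by the name of the read-out), a lower number less inhibition. Compound 1 `C[C@H](NCc1ccc(OCCCCN2CCN(c3cccc4c3ccn4Cc3cccc(Cl)c3)CC2)cc1)C(N)=O` gives 24%. Compound 2 `C[C@H](NCc1ccc(OCCCCCN2CCN(c3cccc4c3ccn4Cc3cccc(Cl)c3)CC2)cc1)C(N)=O` gives 43%, and the difference between the cores of compound 1 and compound 2 is not broken down here; its value stands second highest of the three. Compound 3 `C#CCN(C)Cc1ccc(OCCCCN2CCN(c3cccc4c3ccn4Cc3cccc(Cl)c3)CC2)cc1` gives 85%, the highest of the three, with the steps to compound 1 and to compound 2 both beyond the scatter.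

Compound 3 arises from compound 1 by a single change, (methyl(propargyl)amino in place of (1-carbamoylethyl)amino on a saturated chain carbon bound to an aromatic carbon). That change is worth a number 61 percentage points higher from compound 1 to compound 3 (beyond the scatter), a large step.

Compound 4 `C#CCN(C)Cc1ccc(OCCCCCN2CCN(c3cccc4c3ccn4Cc3cccc(Cl)c3)CC2)cc1` has not yet been measured in this assay. It arises from compound 2 by methyl(propargyl)amino in place of (1-carbamoylethyl)amino on a saturated chain carbon bound to an aromatic carbon, the same change, made in the same place, that turned compound 1 into compound 3. Compound 2 starts from 43%, a higher point than compound 1. The expected step of a number 47 percentage points higher from compound 2 to compound 4 (beyond the scatter) is smaller than the measured a number 61 percentage points higher from compound 1 to compound 3 (beyond the scatter) because compound 2 gives 43%, a higher starting number than compound 1, so less room remains for the number to rise. Compound 4 is therefore expected to reach about 90%, most likely between 75% and 99%.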

Compound 4, a percentage reported as inhibition, at one concentration (the size of the read-out at that concentration, not a potency): 100%
The estimate for compound 4 lay 10 percentage points below the measured number, outside the stated range (above it).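

In this assay, putting methyl(propargyl)amino in place of (1-carbamoylethyl)amino on a saturated chain carbon bound to an aromatic carbon again makes a large difference, a number 57 percentage points higher from compound 2 to compound 4 (beyond the scatter). Set beside the earlier example, the step carries over from one core to the other at much the same size: the same change on two cores in this assay, a number 61 percentage points higher (beyond the scatter) from compound 1 to compound 3 and a number 57 percentage points higher (beyond the scatter) from compound 2 to compound 4, 4 percentage points apart, within the scatter of two such steps

Going by these compounds alone, this agreement rests on only two pairs with closely similar cores, so it says nothing about how the change would behave on a core of a different kind. Compound 4 also gives 100%, the top of a percentage scale, where a still larger effect could not show, and a reading at a single concentration is not a potency.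

The compounds shown leave open which part of the entering group goes with the step, since a dimethylamino group or a propargylamino group without the methyl would separate the role of the triple bond from that of the methyl on the nitrogen. Going by these compounds, it also remains open whether the same step would appear with a shorter or a longer chain joining the oxygen to the piperazine nitrogen, or with a different group in place of the chlorobenzyl group.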